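A Benzyl Ether Cut Back to Ethyl

A few compounds are considered here, and "the series" means these few. Any claim that something is new, unique, unknown or untested is made for them only; others in the source may bear on it.

Three measured compounds share one core. Compound 1 `O=[N+]([O-])c1cccc(COCNc2n[n+]([O-])c3ccccc3[n+]2[O-])c1` carries nitro on an aromatic carbon of its benzyl group; in a functional assay on A549 cells (Homo sapiens) for cytotoxicity, read by MTT assay, with a stated time of 72 h (a higher number here means a weaker inhibitor, a lower number a stronger inhibitor), compound 1 gives 2890 nM. Compound 2 `[O-][n+]1nc(NCOCc2ccccc2)[n+]([O-])c2ccccc21` has hydrogen in that place, and in this assay compound 2 gives 10800 nM. Compound 3 `[O-][n+]1nc(NCOCc2ccc(C(F)(F)F)cc2)[n+]([O-])c2ccccc21` bears trifluoromethyl there; in this assay compound 3 gives 8420 nM. Compound 2 thus holds the highest number of the three: its nearest is compound 3, since a 1.3-fold lower number from compound 2 to compound 3 (0.11 log units; within the scatter), while compound 1 sits furthest away, as a 3.7-fold higher number from compound 1 to compound 2 (0.57 log units; beyond the scatter).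

Compound 4 `CCOCNc1n[n+]([O-])c2ccccc2[n+]1[O-]` differs from compound 2 by methyl in place of phenyl on a saturated chain carbon bound to an oxygen on a saturated carbon. Going by the values given here, both measured steps concern groups on an aromatic carbon of the phenyl that here disappears altogether, so neither bears directly on this change, and the data hold no step that removes the phenyl. Any reading of compound 4 in this assay is therefore weakly founded. Compound 4 is expected at about 15000 nM, with a range from 5000 nM to 45000 nM. That estimate means a step of a 1.4-fold higher number from compound 2 to compound 4 (0.14 log units; within the scatter), expected to lie near the edge of the scatter.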

Compound 4, half-maximal inhibitory concentration: 10500 nM
Estimate against measurement, compound 4: 1.4-fold (0.15 log units) above, within the range that was stated.
By their numbers in this assay, from the lowest: compound 1; then compounds 3, 4 and 2 (each within the scatter of the next).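

In this assay, methyl in place of phenyl gives a 1.0-fold lower number from compound 2 to compound 4 (0.01 log units; within the scatter), so the whole phenyl can go from this place without a shift beyond the scatter. The earlier compounds shown here spoke only of groups on that phenyl, where hydrogen in place of nitro gave a 3.7-fold higher number from compound 1 to compound 2 (0.57 log units; beyond the scatter), and this result adds that the unsubstituted phenyl, set against methyl, makes no readable difference. No measurement at hand offers an explanation for this result.

The compounds shown leave open whether a longer chain, such as propyl or butyl, would stay within the scatter of compound 2 and compound 4. They also leave open what an amine or a carboxylic acid at the end of this chain would give.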